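From 4-Fluorophenyl to Pyrimidin-5-yl: an Expected Cytotoxicity

The source may report more compounds than this note shows. Statements on the series, on what has been measured and on what is new or still open speak of the compounds shown alone.

Compound 3 `O=C(CCCCCCc1nc2ccc(-c3ccc(F)cc3)cc2[nH]1)NO` gives the lowest of the three numbers in a functional assay on SK-OV-3 cells (Homo sapiens) for cytotoxicity (on this read-out lower numbers stand for stronger inhibition and higher numbers for weaker inhibition), at 1200 nM. Compound 2 `O=C(CCCCCCc1nc2ccc(F)cc2[nH]1)NO` gives 1900 nM, and the step of a 1.6-fold lower number from compound 2 to compound 3 (0.20 log units; within the scatter) is within the scatter, so the two cannot be ordered. Compound 1 `O=C(CCCCCc1nc2ccccc2[nH]1)NO` gives 11000 nM, clearly weaker. Compound 4 `O=C(CCCCCCc1nc2ccc(-c3cncnc3)cc2[nH]1)NO` differs from compound 3 by pyrimidin-5-yl in place of 4-fluorophenyl on an aromatic carbon. For the measured compounds named here, no measured step replaces one aromatic ring with another; the only step available, a 1.6-fold lower number from compound 2 to compound 3 (0.20 log units; within the scatter), concerns a different change and was small. The expectation for compound 4 is therefore no step beyond the scatter, with wide uncertainty. Compound 4 is estimated at 1500 nM, ranging from 500 nM to 4500 nM. This estimate means an expected step of a 1.3-fold higher number from compound 3 to compound 4 (0.10 log units; within the scatter).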

Compound 4, half-maximal inhibitory concentration: 2600 nM
Beside the measured number, compound 4's estimate is 1.7-fold (0.24 log units) below it; the measured number falls inside the stated range.
By their numbers in this assay, from the lowest: compounds 3, 2 and 4 (each within the scatter of the next, the first and the last beyond it); then compound 1.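

At this position the choice of aromatic ring does register: in this assay, putting pyrimidin-5-yl in place of 4-fluorophenyl gives a modest step beyond the scatter (a 2.2-fold higher number from compound 3 to compound 4 (0.34 log units; beyond the scatter)). Set against the small fluoro group, pyrimidin-5-yl gives a step within the scatter (a 1.4-fold higher number from compound 2 to compound 4 (0.14 log units; within the scatter)), so those two compounds cannot be ordered. Nothing measured here gives a reason for the shift between the two rings.

Still open, as far as these compounds go, is whether the shift follows the two ring nitrogens or the loss of the fluorine. Plain phenyl or pyridin-3-yl at this position would help separate the two.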